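The source may report more compounds than this note shows. Statements on the series, on what has been measured and on what is new or still open speak of the compounds shown alone.

Compound 1 `NC(=S)N/N=C/c1cc2ccccc2s1` reaches only the assay limit in a functional assay on HL-60 cells (Homo sapiens) for antiproliferative activity, read by sulforhodamine B assay, with a stated time of 72 h (on this read-out lower numbers stand for stronger inhibition and higher numbers for weaker inhibition), giving > 100000 nM. Compound 2 `COc1cccc(NC(=S)N/N=C/c2ccc3ccccc3n2)c1` gives the sole numerical value in this assay, 71200 nM, which places it at the weak end of the range shown. The remaining value sits at the limit (the limit of > 100000 nM in this assay, at which 1 of the 2 values shown sits). Compound 3 `S=C(NCc1ccccc1)N/N=C/c1ccc2ccccc2n1` differs from compound 2 by benzyl in place of 3-methoxyphenyl on an amide-type nitrogen. Among the compounds with values here, no measured step covers such a change, so compound 3 is expected to shift only a 1.1-fold higher number from compound 2 to compound 3 (0.05 log units; within the scatter), a move within the scatter. Compound 3 is therefore estimated at 80000 nM, with a range from 30000 nM to 200000 nM.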

Compound 3, half-maximal inhibitory concentration: 21900 nM
The estimate for compound 3 lay 3.7-fold (0.56 log units) above the measured number, and the stated range ends above it.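

In this assay, the amide-type nitrogen proves to be a place where the number can move: benzyl in place of 3-methoxyphenyl gives a 3.3-fold lower number from compound 2 to compound 3 (0.51 log units; beyond the scatter). Both groups carry one six-membered aromatic ring of carbon only, so a change that keeps this ring is still enough to shift the read-out. No measured property among the compounds shown accounts for the step. This single step cannot separate the loss of the methoxy group from the change in how the ring is attached. On these data alone, how a plain phenyl or a longer phenethyl chain would fare on this nitrogen stays open.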